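The compounds below may be only part of what the source reports. "The series", "measured", "known", "first", "only" and "open" are said of these compounds alone.

Measured so far:
compound 1 `COc1ccc(-c2cc(=O)c3c(OC)cc(OC)cc3n2Cc2ccccc2)cc1`: in a functional assay on SUP-B15 cells (Homo sapiens) for antiproliferative activity, with a stated time of 72 h (on this read-out higher numbers stand for an effect only at larger amounts of compound and lower numbers for an effect already at smaller amounts), compound 1 gives > 34400 nM, which is a limit of the assay and not a number.
compound 2 `COc1ccc(-c2cc(=O)c3c(OC)cc(OC)cc3n2S(=O)(=O)c2cc(F)c(F)c(F)c2)cc1`: in this assay compound 2 gives > 65500 nM, again a limit of the assay rather than a number.

Compound 2 stands at the limit of > 65500 nM in this assay, at which 1 of the 2 values shown sits. Within the data shown here, the only other value shown sits at the limit of > 34400 nM in this assay, at which 1 of the 2 values shown sits. Among the measured compounds shown here, with both values at limits, no step between measured compounds can be sized, and neither compound shows an effect within the tested range.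

Compound 3 `COc1ccc(-c2cc(=O)c3c(OC)cc(OC)cc3n2S(=O)(=O)Cc2ccccc2)cc1` is not yet measured. It differs from compound 2 in one place: benzyl in place of 3,4,5-trifluorophenyl on a sulfonyl sulfur. The sulfonyl on the aromatic nitrogen is kept; only the group on the sulfonyl sulfur changes. For the measured compounds named here, no measured step is available to guide the expectation. For compound 3 the step in this assay is expected to be none beyond the scatter, that is an at least 1.0-fold lower number from compound 2 to compound 3 (0.03 log units; that floor lies within the scatter), and compound 3 is expected to stay at a limit of the assay. In this assay compound 3 is expected to give 60000 nM, with a range from 20000 nM to 200000 nM.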

Compound 3, half-maximal effective concentration: > 34400 nM
Compound 3 was reported as a limit; the forecaster's own chance of this, stated with the estimate: 80%; the middle value lies beyond the limit too.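

In this assay compound 1, compound 2 and compound 3 all stand at limits of the assay, and the steps to compound 3 from compound 2 and from compound 1 cannot be read. The compounds shown leave open whether any group on the sulfonyl sulfur or on the aromatic nitrogen gives a measurable effect on these cells.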